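Swapping fluoro for methoxy in a cytotoxicity series

This account rests on a few compounds, and the source may have more. Where it says the series, first, only, none or still open, it means among the compounds named here.

Four compounds share a common layout, and three of them have been tested in a functional assay on MDA-MB-231 cells (Homo sapiens) for cytotoxicity, read by sulforhodamine B assay, with a stated time of 48 h; on this read-out lower numbers stand for stronger inhibition of growth and higher numbers for weaker inhibition of growth. Compound 1 `Cc1ccc(-c2ccc([N+](=O)[O-])cc2)n1-c1ccc(-c2nc3ccc(F)cc3s2)cc1` gives 1670 nM in this assay. Compound 2 `COc1ccc2nc(-c3ccc(-n4c(C)ccc4-c4ccc([N+](=O)[O-])cc4)cc3)sc2c1` differs from compound 1 by a single change, (methoxy in place of fluoro on an aromatic carbon), and in this assay compound 2 gives 4560 nM; the resulting step is a 2.7-fold higher number from compound 1 to compound 2 (0.44 log units; beyond the scatter). Compound 3 `COc1cc2nc(-c3ccc(-n4c(C)ccc4-c4ccc(F)cc4)cc3)sc2c(OC)c1OC` carries a different core from compound 1; the difference between the two cores is not broken down here. In this assay, going by the values given here, compound 3 gives 3940 nM, a number that lies within the usual scatter of the one for compound 2.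

Compound 4 `COc1ccc(-c2ccc(C)n2-c2ccc(-c3nc4cc(OC)c(OC)c(OC)c4s3)cc2)cc1` has not yet been measured. It differs from compound 3 by methoxy in place of fluoro on an aromatic carbon. Among the compounds with values here, this is the same kind of change as the one from compound 1 to compound 2, but not the same change: there the methoxy enters on a ring that is part of a fused or bridged system of two rings, meta to a fused ring and para to a fused ring, whereas here it enters on a six-membered aromatic ring of carbon only, para to a large group. Within the data shown here, only one measured pair shows this kind of change, and it sits at a different place, so the expectation is loose. For compound 4 the estimated step is a 1.5-fold higher number from compound 3 to compound 4 (0.18 log units; within the scatter), a somewhat smaller shift than the measured precedent, since a 2.7-fold higher number from compound 1 to compound 2 (0.44 log units; beyond the scatter) was observed at a different place in the molecule. Compound 4 is therefore expected to give about 6000 nM in this assay, most likely between 2500 nM and 14000 nM.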

Compound 4, concentration for 50% growth inhibition: 2240 nM
Estimate against measurement, compound 4: 2.7-fold (0.43 log units) above, and the stated range ends above it.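

In this assay, putting methoxy in place of fluoro, which turns the 4-fluorophenyl of compound 3 into the 4-methoxyphenyl of compound 4, gives a 1.8-fold lower number from compound 3 to compound 4 (0.25 log units; within the scatter), so on this core the two compounds cannot be told apart. Set beside the earlier swap of fluoro for methoxy, the new step does not match it: the same change on two cores in this assay, a 2.7-fold higher number (0.44 log units; beyond the scatter) from compound 1 to compound 2 and a 1.8-fold lower number (0.25 log units; within the scatter) from compound 3 to compound 4, 4.8-fold (0.68 log units) apart, beyond the scatter of two such steps. This shows that the result of the swap on one core did not carry over to the other in this pair of examples, but it does not show why: the two pairs differ both in their cores and in where the swap sits, the data cannot separate these two differences, and one pair on each core gives no general rule.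

The compounds shown leave open whether the outcome of this swap follows its place in the molecule or the rest of the core, a question that the same swap at the same place on both cores could help to settle. They also leave open how other groups in place of the methoxy of compound 4, such as an amine, a carboxylic acid or a longer chain, would behave on this read-out.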